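The compounds below may be only part of what the source reports. "The series", "measured", "known", "first", "only" and "open" are said of these compounds alone.

Measured so far in an assay on cells for agonist activity at ecdysone receptor (Bombyx mori), read by a luciferase reporter, with a stated time of 24 h; on this read-out lower numbers stand for an effect already at smaller amounts and higher numbers for an effect only at larger amounts of compound:
Compound 1 `CC(C)(C)N(NC(=O)c1ccccc1Br)C(=O)c1ccccc1Cl` gives 316 nM.
Compound 2 `CC(C)(C)N(NC(=O)c1ccc(Cl)cc1)C(=O)c1ccccc1Cl` gives 115 nM.
Compound 3 `CC(C)(C)N(NC(=O)c1ccc(Br)cc1)C(=O)c1ccccc1Cl` gives 33.9 nM.

Compound 2 stands second highest of the three numbers in this assay; compound 1 lies nearest, with a 2.7-fold lower number from compound 1 to compound 2 (0.44 log units; beyond the scatter) between them, and compound 3 furthest, with a 3.4-fold lower number from compound 2 to compound 3 (0.53 log units; beyond the scatter). Compound 4 `Cc1cc(C)cc(C(=O)N(NC(=O)c2ccc(Cl)cc2)C(C)(C)C)c1` has not yet been measured. It differs from compound 2 in one place: 3,5-dimethylphenyl in place of 2-chlorophenyl on a carbonyl carbon.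

For the measured compounds named here, none of the measured steps touches this part of the molecule. Every step that has been measured — a 2.7-fold lower number from compound 1 to compound 2 (0.44 log units; beyond the scatter), a 9.3-fold lower number from compound 1 to compound 3 (0.97 log units; beyond the scatter) and a 3.4-fold lower number from compound 2 to compound 3 (0.53 log units; beyond the scatter) — changes the aryl group on the other carbonyl carbon, the one bonded to the amide hydrogen, while the 2-chlorophenyl on the carbonyl carbon next to the tert-butyl-bearing nitrogen is kept in all three. Going by the values given here, the data therefore give no measured step of the kind that is now taken.

Among the compounds with values here, with no step to lean on, the expectation for compound 4 rests on compound 2 alone, which gives 115 nM: the step is estimated as a 1.4-fold lower number from compound 2 to compound 4 (0.16 log units; within the scatter), that is, no change beyond the scatter with a wide margin either way. Compound 4 is thus estimated at 80 nM, within 15 nM to 500 nM.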

Compound 4, half-maximal effective concentration: 19.1 nM
Compound 4: middle estimate off by 4.2-fold (0.62 log units), on the high side; low and high end bracket the measured number.
By their numbers in this assay, from the lowest: compounds 4 and 3 (each within the scatter of the next); then compound 2; then compound 1.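

In this assay, 3,5-dimethylphenyl in place of 2-chlorophenyl gives a 6.0-fold lower number from compound 2 to compound 4 (0.78 log units; beyond the scatter). The aryl group on the carbonyl carbon whose other neighbours are the amide-type nitrogen, kept the same in compound 1, compound 2 and compound 3, therefore also moves the number, and here the move goes to a lower number, with chlorine replaced by carbon only. No measurement at hand offers an explanation for this step.

The compounds shown do not separate what leaving 2-chlorophenyl contributes from what entering 3,5-dimethylphenyl contributes, a question that a plain phenyl, 3-methylphenyl or 3,5-dimethoxyphenyl at this place would bear on. Also open, on these data alone, is whether the same exchange gives a step of similar size on the core of compound 3, which carries a 4-bromophenyl group.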